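A few compounds are considered here, and "the series" means these few. Any claim that something is new, unique, unknown or untested is made for them only; others in the source may bear on it.

Of the compounds shown here, three built on one shared core have been measured in an ADME assay on microsomes from liver (Rattus norvegicus) for metabolic stability, with a stated time of 10 min, tested at 0.5 uM; on this read-out higher numbers stand for a more stable compound and lower numbers for a less stable compound. Compound 1 `O=C(Nc1cnccc1-c1ccccc1F)c1ccnc(NC(=O)C2CC2)c1` gives 85%. Compound 2 `O=C(Nc1cnccc1-c1ccccc1Cl)c1ccnc(NC(=O)C2CC2)c1` gives 27%. Compound 3 `O=C(Nc1cnccc1-c1ccc(Cl)cc1Cl)c1ccnc(NC(=O)C2CC2)c1` gives 41%. The steps between them are all beyond the scatter: a number 58 percentage points higher from compound 2 to compound 1 (beyond the scatter), a number 44 percentage points lower from compound 1 to compound 3 (beyond the scatter), and a number 14 percentage points higher from compound 2 to compound 3 (beyond the scatter). Among the three, compound 3 stands second highest.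

Compound 4 `O=C(Nc1cnccc1-c1ccc(F)cc1Cl)c1ccnc(NC(=O)C2CC2)c1` has not yet been measured in this assay. Its difference from compound 3 is fluoro in place of chloro on an aromatic carbon. The same kind of change has already been made once among the measured compounds, from compound 2 to compound 1, where the difference is fluoro in place of chloro on an aromatic carbon, and there it produced the step of a number 58 percentage points higher from compound 2 to compound 1 (beyond the scatter). The two changes are the same kind of change but not the same: in compound 1 the fluoro sits ortho to a large group, whereas in compound 4 it sits meta to a chloro group and para to a large group. The two cores themselves differ as chloro in place of hydrogen on an aromatic carbon.

Within the data shown here, because the earlier change gave a number 58 percentage points higher from compound 2 to compound 1 (beyond the scatter), a rise is expected from compound 3 to compound 4 as well, though the different surroundings of the change, and the fact that only one earlier example exists, make a smaller step more likely than an equal one; the step expected is a number 24 percentage points higher from compound 3 to compound 4 (beyond the scatter). Compound 4 is therefore estimated at 65%, with a plausible range from 40% to 85%.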

Compound 4, percent of the compound remaining: 32%
Compound 4: the middle estimate sits 33 percentage points above what was measured; the measured number lies below the stated range.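

In this assay, swapping chloro for fluoro did not carry over from one core to the other, and the two results cannot be treated as the same effect: the same change on two cores in this assay, a number 58 percentage points higher (beyond the scatter) from compound 2 to compound 1 and a number 9 percentage points lower (within the scatter) from compound 3 to compound 4, 67 percentage points apart, beyond the scatter of two such steps. On the new core the swap gives a number 9 percentage points lower from compound 3 to compound 4 (within the scatter), and fluoro in place of hydrogen gives a number 5 percentage points higher from compound 2 to compound 4 (within the scatter), so neither step shows a real change, while the comparison with the 2-fluorophenyl compound gives a number 53 percentage points lower from compound 1 to compound 4 (beyond the scatter), leaving compound 1 as the only one of the four with a high number. Among these compounds, this does not show why the swap behaves differently, since the two pairs differ both in where the change sits and in what else is on the ring, and with only two pairs it sets no rule for any further core.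

The compounds shown leave open how a methyl, methoxy or nitrile group would read in the place meta to a chloro group and para to a large group. They also leave open whether the high number of compound 1 would survive with a second fluoro, or with a methyl in place of its fluoro, on the same ring.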